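Swapping a Dimethylphenyl for a Cyanophenyl: Cytotoxicity Outlook

The source may report more compounds than this note shows. Statements on the series, on what has been measured and on what is new or still open speak of the compounds shown alone.

Compound 1 `COc1ccc(F)cc1CNCCCNc1ccnc2cc(Cc3cc(C)cc(C)c3)ccc12` was tested in an ADME assay on HepG2 cells (Homo sapiens) for cytotoxicity, read by luminescence, CellTiter-Glo and ATP content, with a stated time of 72 h (a lower number here means that less compound is needed, a higher number that more compound is needed for the effect), where compound 1 gives 940 nM. Among the three measured compounds it holds the second highest number. Compound 2 `CCC(CC)c1ccc2c(NCCCNCc3cccc(OC)c3O)ccnc2c1` gives 410 nM, a lower number than compound 1, while compound 3 `Cc1cc(C)cc(Cc2ccc3c(NCCCNCc4ccco4)ccnc3c2)c1` gives 6270 nM, the highest of the three. Going by the values given here, the only step between compounds differing in a single place is a 6.7-fold higher number from compound 1 to compound 3 (0.82 log units; beyond the scatter), and it concerns the group on a saturated chain carbon bound to an amine nitrogen, at the other end of the molecule.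

Compound 4 `COc1ccc(F)cc1CNCCCNc1ccnc2cc(Cc3ccc(C#N)cc3)ccc12` differs from compound 1 elsewhere: 4-cyanophenyl in place of 3,5-dimethylphenyl on a saturated chain carbon bound to an aromatic carbon. Among the compounds with values here, no measured step touches this part of the shared core, so the direction of the change cannot be read from the data, and only a step of modest size is expected. Compound 4 is therefore expected to give 1500 nM, with a range from 500 nM to 5000 nM. This estimate corresponds to an expected step of a 1.6-fold higher number from compound 1 to compound 4 (0.20 log units; within the scatter).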

Compound 4, half-maximal effective concentration: 6050 nM
Compound 4: the middle estimate sits 4.0-fold (0.61 log units) below what was measured; measured number above the stated range.
By their numbers in this assay, from the lowest: compound 2; then compound 1; then compounds 4 and 3 (each within the scatter of the next).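

In this assay, 4-cyanophenyl in place of 3,5-dimethylphenyl on a saturated chain carbon bound to an aromatic carbon gives a 6.4-fold higher number from compound 1 to compound 4 (0.81 log units; beyond the scatter). Going by these compounds alone, this is the first measured step at this place, and it shows that the number responds here too, not only at the group on a saturated chain carbon bound to an amine nitrogen, where the earlier change gave a 6.7-fold higher number from compound 1 to compound 3 (0.82 log units; beyond the scatter). No measurement at hand offers a reason for this rise.

The change takes away two methyl groups and brings in a nitrile in a single move, so the compounds shown leave open which of the two carries the step. Going by these compounds, a plain phenyl or a 4-methylphenyl at this place would separate them, and whether the step holds alongside furan-2-yl also stays open.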